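A three-membered ring joins a compound stuck at a limit

The source may hold more compounds than are shown below. What is called first, only, known or untested is meant among the compounds shown, and "the series" means these compounds.

In a physicochemical assay for solubility, with a stated time of 24 h, at pH 6.8 (on this read-out lower numbers stand for lower solubility and higher numbers for higher solubility), compound 1 `O=C(NC[C@@H]1[C@H]2CN(C(=O)/C=C/c3cc(Cl)cc(Cl)c3)C[C@@H]12)c1ccc2[nH]c(=O)oc2c1` gives < 1 ug/mL as a limit of the assay and not a number. Compound 2 `O=C(NC[C@@H]1[C@H]2CN(C(=O)CCc3cc(Cl)cc(Cl)c3)C[C@@H]12)c1ccc2[nH]c(=O)oc2c1` gives < 1 ug/mL as a limit too, so that is all that can be said of where it stands. Among the compounds with values here, the one measured step is a step that the two limits leave unreadable from compound 1 to compound 2 and it offers no size to carry forward.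

Compound 3 `O=C(NC[C@@H]1[C@H]2CN(C(=O)C3CC3c3cc(Cl)cc(Cl)c3)C[C@@H]12)c1ccc2[nH]c(=O)oc2c1` differs from compound 2 through a group of 11 heavy atoms (9 carbon, 2 chlorine; one three-membered non-aromatic ring of carbon only, one six-membered aromatic ring of carbon only) in place of a group of 10 heavy atoms (8 carbon, 2 chlorine; one six-membered aromatic ring of carbon only), on a carbonyl carbon and the group that enters brings one three-membered non-aromatic ring of carbon only, with no net charge on either group. For compound 1 and compound 2 alike the evidence is the limit of < 1 ug/mL in this assay, at which 2 of the 2 values shown sit, and it holds no readable step. No step beyond the usual scatter is therefore expected in this assay and compound 3 may well be reported only as a limit again. The expected step that the limit leaves unreadable from compound 2 to compound 3 is an estimate set against a limit and not against a number. The estimate for compound 3 is 0.7 ug/mL with an expected range running from 0.3 ug/mL to 2 ug/mL at its two ends.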

Compound 3, solubility: < 1 ug/mL
Compound 3: a limit, no number; the forecaster's own chance of this, stated with the estimate: 85%; the middle value lies beyond the limit too.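

In this assay compound 3 gives only a limit and not a number, as do compound 1 and compound 2, so no step among these compounds can be read: the limit of < 1 ug/mL in this assay, at which 3 of the 3 values shown sit.

The compounds shown leave open whether the 2-(3,5-dichlorophenyl)ethenyl group, the 2-(3,5-dichlorophenyl)ethyl group and the group with the three-membered ring, each on a carbonyl carbon, differ at all in this assay.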